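The source may hold more compounds than are shown below. What is called first, only, known or untested is meant among the compounds shown, and "the series" means these compounds.

Among the compounds with values here, compound 3 `CSc1nc2cccc(C(=O)O)c2n1Cc1ccc(-c2ccccc2-c2noc(O)n2)cc1` stands at the top of the three measured members: in a functional assay on the whole organism for inhibition, with Rattus norvegicus as the target, with a stated time of 7 h, at a dose of 1 mg/kg by the oral route (a lower number here means less inhibition, a higher number more inhibition at the dose given (going by the name of the read-out)), compound 3 gives 100%. Compound 1 `CCCc1nc2cccc(C(=O)O)c2n1Cc1ccc(-c2ccccc2-c2noc(O)n2)cc1` gives 88% in the same test, and compound 2 `COc1nc2cccc(C(=O)O)c2n1Cc1ccc(-c2ccccc2-c2noc(O)n2)cc1` gives 88%. The two measured steps that reach compound 3 are alike in size: a number 12 percentage points higher from compound 1 to compound 3 (beyond the scatter) and a number 12 percentage points higher from compound 2 to compound 3 (beyond the scatter), whereas no change at the digits printed from compound 1 to compound 2 (within the scatter). Compound 4 `CCNc1nc2cccc(C(=O)O)c2n1Cc1ccc(-c2ccccc2-c2noc(O)n2)cc1` differs from compound 3 in one place: ethylamino in place of methylsulfanyl on an aromatic carbon. Within the data shown here, no measured step exchanges methylsulfanyl for an amino group, so the steps that end at compound 3 offer only indirect guidance; they show that the group on this carbon shifts the read-out by a modest amount at most, and that all three groups tried leave the inhibition high. Compound 4 is therefore expected to stay near the top, with a small downward step a number 10 percentage points lower from compound 3 to compound 4 (within the scatter) allowed for the untried group, so that compound 4 is estimated at 90%, within 75% to 100%.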

Compound 4, a percentage reported as inhibition, in the whole organism at one dose (the size of the read-out at that dose, not a potency): 6%
For compound 4 the middle estimate is 84 percentage points above the measured one; the measured number lies below the stated range.
By their numbers in this assay, from the lowest: compound 4; then compounds 1 and 2 (each within the scatter of the next); then compound 3.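

The position is far less forgiving than propyl, methoxy and methylsulfanyl suggested: in this assay, ethylamino on this aromatic carbon between two ring nitrogen atoms gives a number 94 percentage points lower from compound 3 to compound 4 (beyond the scatter) and a number 82 percentage points lower from compound 2 to compound 4 (beyond the scatter) and also a number 82 percentage points lower from compound 1 to compound 4 (beyond the scatter) in the same test. Within the data shown here, the high read-out of the earlier compounds therefore does not extend to every small group here, and a single change at this carbon can remove nearly all of the inhibition at the dose given. Ethylamino carries a hydrogen-bond donor where methylsulfanyl carries none, but nothing available explains the drop.

As far as these compounds go, whether the loss goes with the ring-bound nitrogen or with the ethyl chain stays open. An unsubstituted amine, methylamino, ethoxy or ethylsulfanyl on this carbon would help to separate the two.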